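Moving the Fluorine on the Benzyl Group of Compound 3

This account rests on a few compounds, and the source may have more. Where it says the series, first, only, none or still open, it means among the compounds named here.

Compound 1 `COc1ccc2[nH]c3c(c2c1)CCNC31CCN(Cc2ccccc2)CC1`: in an assay on FRT cells for positive allosteric modulation of Cystic fibrosis transmembrane conductance regulator variant N1303K (Homo sapiens), in the presence of a further agent that is not named here (on this read-out lower numbers stand for an effect already at smaller amounts and higher numbers for an effect only at larger amounts of compound), compound 1 gives 12600 nM.
Compound 2 `COc1ccc2[nH]c3c(c2c1)CCNC31CCN(Cc2c(F)ccc(Cl)c2F)CC1`: in this assay compound 2 gives 1500 nM.
Compound 3 `COc1ccc2[nH]c3c(c2c1)CCNC31CCN(Cc2ccc(Br)c(F)c2)CC1`: in this assay compound 3 gives 1800 nM.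

All three compounds share one core and differ only in the aromatic group on the saturated chain carbon bound to an amine nitrogen in a ring. Compound 3 stands second highest of the three numbers: its nearest neighbour is compound 2, a 1.2-fold higher number from compound 2 to compound 3 (0.08 log units; within the scatter), and its furthest is compound 1, a 7.0-fold lower number from compound 1 to compound 3 (0.85 log units; beyond the scatter).

Compound 4 `COc1ccc2[nH]c3c(c2c1)CCNC31CCN(Cc2ccc(Br)cc2F)CC1` has not yet been measured. It differs from compound 3 in one place: 4-bromo-2-fluorophenyl in place of 4-bromo-3-fluorophenyl on a saturated chain carbon bound to an amine nitrogen in a ring.

Two measured steps replace a bare phenyl with a halogenated one and both are modest: an 8.4-fold lower number from compound 1 to compound 2 (0.92 log units; beyond the scatter) and a 7.0-fold lower number from compound 1 to compound 3 (0.85 log units; beyond the scatter). Going by the values given here, the only step between two halogenated groups, a 1.2-fold higher number from compound 2 to compound 3 (0.08 log units; within the scatter), lies within the scatter, although those groups carry different halogens. Among the compounds with values here, no measured pair shows what a rearrangement of the same atoms, as in compound 4, does. The expectation is therefore no step beyond the scatter: a 1.1-fold lower number from compound 3 to compound 4 (0.02 log units; within the scatter). Compound 4 is estimated to give about 1700 nM, within a range from 700 nM to 4200 nM.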

Compound 4, half-maximal effective concentration: 1600 nM
Estimate against measurement, compound 4: 1.1-fold (0.03 log units) above, and the stated range covers the measured number.
By their numbers in this assay, from the lowest: compounds 2, 4 and 3 (each within the scatter of the next); then compound 1.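

Going by these compounds alone, compound 4 is the first case here in which the same atoms are only rearranged at this position, and in this assay putting 4-bromo-2-fluorophenyl in place of 4-bromo-3-fluorophenyl gives a 1.1-fold lower number from compound 3 to compound 4 (0.05 log units; within the scatter), so this shift of the fluorine leaves the read-out unchanged within the usual scatter. The new group also cannot be separated from the 3-chloro-2,6-difluorophenyl group of compound 2, with a 1.1-fold higher number from compound 2 to compound 4 (0.03 log units; within the scatter), while the change from plain phenyl remains clear, with a 7.9-fold lower number from compound 1 to compound 4 (0.90 log units; beyond the scatter); the three halogenated groups thus form one cluster, well apart from phenyl. Why the read-out tolerates this rearrangement cannot be said, as no measurement bearing on the reason is available.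

The compounds shown leave open what the bromine and the fluorine each contribute alone, which a plain 4-bromophenyl or 2-fluorophenyl group would help to separate. Also open, going by these compounds, is whether the lower number relative to phenyl requires a halogen at all, a question that a methoxy group, an amine or a carboxylic acid on the same ring could address.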